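A Chain-End Aryl Swap and Its Expected Effect

The source may hold more compounds than are shown below. What is called first, only, known or untested is meant among the compounds shown, and "the series" means these compounds.

Measured compounds:
compound 1, `O=C(CCCCC#Cc1cccc([N+](=O)[O-])c1)c1ncc(-c2ccccn2)o1`, 4.8 nM
compound 2, `O=C(CCCCCCc1ccc2ccccc2c1)c1ncc(-c2ccccn2)o1`, 11 nM
compound 3, `O=C(CCCCCCc1ccccc1C(=O)O)c1ncc(-c2ccccn2)o1`, > 600 nM

All three share a core carrying a saturated chain that ends in an aryl group, and they were tested in an assay for inhibition of Fatty-acid amide hydrolase 1 (Rattus norvegicus); a lower number here means a stronger inhibitor, a higher number a weaker inhibitor. Compound 1 gives 4.8 nM and compound 2 gives 11 nM; these two values lie within the usual scatter of each other. Compound 3 stands apart: for compound 3 this assay reports only a limit, > 600 nM, so its inhibition constant is not known as a number. This limit is described by the limit of > 600 nM in this assay, at which 1 of the 3 values shown sits.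

Compound 4, `CSc1cccc(CCCCCCC(=O)c2ncc(-c3ccccn3)o2)c1`, has not yet been measured. It differs from compound 3 in one place: 3-(methylsulfanyl)phenyl in place of 2-carboxyphenyl on a saturated chain carbon, six bonds along the chain from a carbonyl carbon. Compound 4 thus carries an uncharged aryl group at the chain end with no hydrogen-bond donor, as compound 2 does, and compound 2 gives 11 nM in this assay. On that basis compound 4 is expected to move far from the limit seen for compound 3, with the step from compound 3 to compound 4 estimated as an at least 50-fold lower number from compound 3 to compound 4 (1.69 log units; beyond the scatter), a step well beyond the scatter toward stronger inhibition. Compound 4 is estimated at 12 nM, within a range from 3 nM to 50 nM.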

Compound 4, inhibition constant: 4.2 nM
Compound 4: middle estimate off by 2.9-fold (0.46 log units), on the high side, within the range that was stated.
By their numbers in this assay, from the lowest: compounds 4 and 1 (each within the scatter of the next); then compound 2. At a limit, above all of these: compound 3.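

Among the earlier compounds no two differed in one place, so this is the only direct reading at this position, on a saturated chain carbon, six bonds along the chain from a carbonyl carbon: with 3-(methylsulfanyl)phenyl in place of 2-carboxyphenyl, the change is an at least 140-fold lower number from compound 3 to compound 4 (2.15 log units; beyond the scatter). In this assay compound 4 gives 4.2 nM, which shows that on this shared core and this saturated chain the outcome depends strongly on which of these two aryl groups ends the chain. The size of the step remains a bound and not an exact figure, since compound 3 has only a limit and no number: the limit of > 600 nM in this assay, at which 1 of the 4 values shown sits.

The change replaces the carboxylic acid with a methylsulfanyl group and also differs in where the ring carries its group, and the compounds shown do not separate these two differences, so neither can be credited with the step. From the compounds shown here alone, how an amine, a carboxylic acid on a longer chain, or a plain phenyl group would behave at this place in this assay remains open.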